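The source may hold more compounds than are shown below. What is called first, only, known or untested is meant among the compounds shown, and "the series" means these compounds.

Compound 2 `CN1C(=O)C(O)(Cc2nnn[nH]2)c2cc(Cl)ccc21` carries a chloro group on the shared core; in a functional assay on PC-3 cells (Homo sapiens) for antiproliferative activity, read by MTT assay, with a stated time of 48 h (on this read-out lower numbers stand for stronger inhibition and higher numbers for weaker inhibition), compound 2 gives > 100000 nM, which is a limit of the assay rather than a number. From the compounds shown here alone, compound 2 thus sits at the limit of > 100000 nM in this assay, at which 1 of the 2 values shown sits, so its exact position is unknown. Compound 1 `CN1C(=O)C(O)(Cc2nnn[nH]2)c2cc(F)ccc21` bears a fluoro group in the same place, and in this assay compound 1 gives 38200 nM. Going by the values given here, the single measured step, an at least 2.6-fold higher number from compound 1 to compound 2 (0.41 log units; beyond the scatter), is the only guide available. Compound 3 `Cc1ccc2c(c1)C(O)(Cc1nnn[nH]1)C(=O)N2C` differs from compound 2 by methyl in place of chloro on an aromatic carbon. Among the compounds with values here, no measured step exchanges a methyl for a chloro, so the size of this step cannot be read from the data. With compound 2 already at the limit, compound 3 is expected to remain close to it, with an expected at least 1.1-fold lower number from compound 2 to compound 3 (0.04 log units; that floor lies within the scatter). The value for compound 3 in this assay is estimated at 90000 nM, within 30000 nM to 300000 nM.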

Compound 3, half-maximal inhibitory concentration: > 100000 nM
Compound 3 gave a limit, no number (the forecaster's own chance of this, stated with the estimate: 50%); middle value at least 1.1-fold (0.04 log units) away from the limit.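

Compound 3 is a second compound at the limit of this assay, which leaves fluoro as the only group shown on this aromatic carbon that gives a number: the limit of > 100000 nM in this assay, at which 2 of the 3 values shown sit. Methyl in place of fluoro gives an at least 2.6-fold higher number from compound 1 to compound 3 (0.41 log units; beyond the scatter), so the move away from fluoro is not tied to chloro alone, and a carbon group does no better here than the larger halogen can be shown to do. The step between compound 2 and compound 3 cannot be read, as both values are limits.

From the compounds shown here alone, how far apart chloro and methyl really lie therefore stays open. Also open, going by these compounds, is whether a methoxy group or an amine on this aromatic carbon would give a number, as fluoro does, or a limit.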